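Adding chloro to compound 1: a working estimate

The source may report more compounds than this note shows. Statements on the series, on what has been measured and on what is new or still open speak of the compounds shown alone.

Going by the values given here, in a functional assay on the whole organism (strain Sprague-Dawley) for inhibition, with Rattus norvegicus as the target, with a stated time of 10 min (a higher number here means that more compound is needed for the effect, a lower number that less compound is needed), compound 1 (`O=C(O)c1cnc(-c2ccccc2)[nH]c1=O`) gives 50 mg/kg, the highest of the three numbers measured so far. Compound 2 (`COc1ccccc1-c1ncc(C(=O)O)c(=O)[nH]1`) gives 10 mg/kg, and compound 3 (`C=CCOc1ccccc1-c1ncc(C(=O)O)c(=O)[nH]1`) gives 0.5 mg/kg.

The next candidate is compound 4 (`O=C(O)c1cnc(-c2ccc(Cl)cc2)[nH]c1=O`), with this change from compound 1: chloro in place of hydrogen on an aromatic carbon. The closest measured precedents also replace a hydrogen on an aromatic carbon. Methoxy gives a 5.0-fold lower number from compound 1 to compound 2 (0.70 log units; beyond the scatter), a modest step, and allyloxy gives a 100-fold lower number from compound 1 to compound 3 (2.00 log units; beyond the scatter), a large one. The further step a 20-fold lower number from compound 2 to compound 3 (1.30 log units; beyond the scatter) shows that the outcome depends strongly on which group enters, so these two results do not transfer directly to a different group.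

Among the compounds with values here, no chloro compound has been measured, and both precedents involve a larger group than chloro, which adds only one heavy atom. Both measured substitutions lowered the number, which favours the same direction here, but only weakly. A small step is therefore expected, probably not beyond the scatter, and nothing close to the allyloxy step. The expected change is a 1.7-fold lower number from compound 1 to compound 4 (0.22 log units; within the scatter). For compound 4 the estimated value in this assay is 30 mg/kg, with an expected range of 8 mg/kg to 100 mg/kg.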

Compound 4, dose for 50% inhibition: 5 mg/kg
The estimate for compound 4 lay 6.0-fold (0.78 log units) above the measured number, outside the stated range (below it).
By their numbers in this assay, from the lowest: compound 3; then compounds 4 and 2 (each within the scatter of the next); then compound 1.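

Chloro in place of hydrogen, para to a large group, gives a 10-fold lower number from compound 1 to compound 4 (1.00 log units; beyond the scatter) in this assay, so a substituent of 1 heavy atom at this carbon of the six-membered aromatic ring is enough to move the number beyond the scatter. This place is one that neither compound 2 nor compound 3 uses, and the gain from compound 1 is therefore not confined to one carbon of that ring or to groups joined through oxygen; all three single substitutions shown lower the number, and none of the compounds goes against this. Nothing shown explains the size of the chloro step, and no supporting data on its cause are available.

The compounds shown leave open whether methoxy or allyloxy at this same place would match their steps from compound 1, and whether chloro would give a similar step on the carbon carrying those groups. From the compounds shown here alone, it also remains open whether the result is particular to chloro or extends to fluoro, bromo, methyl or an amine at this place.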